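Aryl ethenylcarbonyl variation at the amide nitrogen

This account rests on a few compounds, and the source may have more. Where it says the series, first, only, none or still open, it means among the compounds named here.

Compound 3 `O=C(/C=C/c1cccs1)Nc1ccc2ncnc(Nc3cccc(Cl)c3)c2c1` sits at the weak end of the three measured analogues: in a functional assay on A549 cells (Homo sapiens) for antiproliferative activity, read by MTT assay, with a stated time of 48 h (a lower number here means a stronger inhibitor, a higher number a weaker inhibitor), compound 3 gives 9310 nM, against compound 2 `O=C(/C=C/c1cccnc1)Nc1ccc2ncnc(Nc3cccc(Cl)c3)c2c1` with 4320 nM and compound 1 `Clc1cccc(Nc2ncnc3ccc(NCc4cccc(Br)n4)cc23)c1` with 2950 nM. The steps of a 3.2-fold higher number from compound 1 to compound 3 (0.50 log units; beyond the scatter) and a 2.2-fold higher number from compound 2 to compound 3 (0.33 log units; beyond the scatter) both run toward compound 3. Compound 4 `Cc1cccc(/C=C/C(=O)Nc2ccc3ncnc(Nc4cccc(Cl)c4)c3c2)n1` differs from compound 3 by 6-methylpyridin-2-yl in place of thiophen-2-yl on a double-bonded chain carbon bound to a double-bonded chain carbon. Within the data shown here, only the step from compound 2 bears directly on this change, and there the pyridinyl analogue gave the lower number; the methyl group and the altered ring attachment have no counterpart among the measured compounds. Compound 4 is therefore expected to give a modestly lower number, a 2.1-fold lower number from compound 3 to compound 4 (0.32 log units; beyond the scatter). Compound 4 is estimated at 4500 nM, within 1800 nM to 11000 nM.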

Compound 4, half-maximal inhibitory concentration: 2160 nM
Beside the measured number, compound 4's estimate is 2.1-fold (0.32 log units) above it; measured number inside the range.
By their numbers in this assay, from the lowest: compounds 4, 1 and 2 (each within the scatter of the next); then compound 3.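

In this assay, 6-methylpyridin-2-yl in place of thiophen-2-yl gives a 4.3-fold lower number from compound 3 to compound 4 (0.63 log units; beyond the scatter), so both pyridinyl groups now read lower than thiophen-2-yl at this position. Between the two pyridinyl groups, the step is a 2.0-fold lower number from compound 2 to compound 4 (0.30 log units; within the scatter), so the methyl group and altered ring attachment, taken together, show no readable change. No available evidence explains the difference between the pyridinyl and thiophenyl rings.

On these data alone, the separate contributions of the methyl group and the ring attachment remain open. So does the effect of a dimethylaminomethyl group on the pyridine ring or of a longer chain in place of ethenyl.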